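Chloro in Two Places on Two Cores, Tested Against T47D Cells

The compounds below may be only part of what the source reports. "The series", "measured", "known", "first", "only" and "open" are said of these compounds alone.

Three compounds have been measured in a functional assay on T47D cells (Homo sapiens) for cytotoxicity, with a stated time of 72 h, tested at 50 ug/mL; a higher number here means a stronger effect of the compound at the concentration tested, a lower number a weaker effect:

compound 1 `O=c1[nH]nc2n(c1=O)CCN2c1ccccc1` gives 0%
compound 2 `N/N=C1\NCCN1c1ccccc1Cl` gives 27%
compound 3 `N/N=C1\NCCN1c1ccccc1` gives 0%

Compound 1 and compound 3 rest on different cores, and the difference between the two cores is not broken down here; their values in this assay sit level within the scatter. For the measured compounds named here, the one counted step among the measured compounds is chloro in place of hydrogen on an aromatic carbon, which gave a number 27 percentage points higher from compound 3 to compound 2 (beyond the scatter).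

Compound 4 `O=c1[nH]nc2n(c1=O)CCN2c1cccc(Cl)c1` is the untested member. It differs from compound 1 by chloro in place of hydrogen on an aromatic carbon. Going by the values given here, this is the same kind of change as the one from compound 3 to compound 2, but not the same: in compound 2 the chloro sits ortho to a group of 7 heavy atoms, in compound 4 it sits meta to a large group, and the core underneath is that of compound 1 rather than that of compound 3.

Among the compounds with values here, a step of a number 12 percentage points higher from compound 1 to compound 4 (beyond the scatter) is expected from compound 1 to compound 4, smaller than a number 27 percentage points higher from compound 3 to compound 2 (beyond the scatter), since only that single earlier step on a different core and place supports any rise at all. Compound 4 is therefore estimated at 12%, with a range from 0% to 35%, pending measurement.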

Compound 4, a percentage reported as inhibition, at one concentration (the size of the read-out at that concentration, not a potency): 0%
Beside the measured number, compound 4's estimate is 12 percentage points above it; low and high end bracket the measured number.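

In this assay, chloro in place of hydrogen on an aromatic carbon gave no change at the digits printed from compound 1 to compound 4 (within the scatter). Set beside the earlier step, the same change did not carry over from one core to the other in this pair of examples: the same change on two cores in this assay, a number 27 percentage points higher (beyond the scatter) from compound 3 to compound 2 and no change at the digits printed (within the scatter) from compound 1 to compound 4, 27 percentage points apart, beyond the scatter of two such steps. This does not show that the core alone decides the outcome, since the chloro also stands in a different place in compound 4 than in compound 2, and these two steps cannot separate the two differences.

The compounds shown leave open whether chloro would raise the number on the core of compound 1 if it stood where it stands in compound 2, and whether chloro meta to a large group would raise it on the core of compound 3. They also leave open how other groups in place of that hydrogen, such as an amine, a methoxy group or a carboxylic acid, would behave on either core.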